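A few compounds are considered here, and "the series" means these few. Any claim that something is new, unique, unknown or untested is made for them only; others in the source may bear on it.

In an ADME assay on liver for metabolic stability, with Liver microsome (Homo sapiens) as the target, read by LC-MS, using microsomes, with a stated time of 5 h (on this read-out higher numbers stand for fast clearance and lower numbers for slow clearance), compound 3 (`O[C@H](c1ccccn1)[C@]1(c2ccc(C(F)(F)F)cc2)C[C@H](O)C1`) gives 50 mL/min/kg and stands level with compound 1 (`C[C@]1(O)C[C@](c2ccc(OC(F)(F)F)cc2)([C@H](O)c2ccccn2)C1`) at 50 mL/min/kg and compound 2 (`C[C@]1(O)C[C@@](c2ccc(C(F)(F)F)cc2)([C@H](O)c2ccccn2)C1`) at 50 mL/min/kg with no spread among the three. Compound 4 (`C[C@]1(O)C[C@](c2ccc(C(F)(F)F)cc2)([C@H](O)c2ccccn2)C1`) differs from compound 3 by methyl in place of hydrogen on a saturated ring carbon as methyl in place of hydrogen on a saturated ring carbon. Among the compounds with values here, no measured pair shows this change alone, so the evidence is indirect. Compound 2 also carries that methyl and gives 50 mL/min/kg without any difference from compound 3. In this assay the expected step of no change at the digits printed from compound 3 to compound 4 (within the scatter) stays within the scatter, with no direction foreseen. Compound 4 is estimated to give 50 mL/min/kg with 30 mL/min/kg to 80 mL/min/kg as the expected range.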

Compound 4, clearance: 33.3 mL/min/kg
Compound 4: the middle estimate sits 1.5-fold (0.18 log units) above what was measured, within the range that was stated.
By their numbers in this assay, from the lowest: compounds 4, 1, 2 and 3 (each within the scatter of the next).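

In this assay, within the data shown here, the methyl in place of hydrogen on a saturated ring carbon can now be read alone, as a 1.5-fold lower number from compound 3 to compound 4 (0.18 log units; within the scatter), which the earlier compounds could not show. The other two changes can also be read, with a 1.5-fold lower number from compound 2 to compound 4 (0.18 log units; within the scatter) for configuration and a 1.5-fold lower number from compound 1 to compound 4 (0.18 log units; within the scatter) for trifluoromethyl in place of trifluoromethoxy on an aromatic carbon, so none of the three steps leaves the scatter. The configuration step isolates one kind of change: the fact that compounds 2 and 4 differ only in the configuration as drawn. From the compounds shown here alone, whether an ethyl group, an amine or a carboxylic acid on this ring carbon would give a clearance beyond the scatter stays open.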